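Oxetane-bearing analogues on the shared core: next step

The compounds below may be only part of what the source reports. "The series", "measured", "known", "first", "only" and "open" are said of these compounds alone.

Values in an assay on isolated protein for inhibition of retinal dehydrogenase 2 (Homo sapiens) (on this read-out higher numbers stand for weaker inhibition and lower numbers for stronger inhibition), so far:
compound 1 `CC(Sc1nc2nn(C3COC3)cc2c(=O)n1-c1ccccc1)c1ccccc1` gives 65 nM
compound 2 `CC(Sc1nc2nn(C3(C)COC3)cc2c(=O)n1-c1ccccc1)c1ccccc1` gives 112 nM
compound 3 `COc1ccccc1C(C)Sc1nc2c(cnn2C)c(=O)n1-c1ccccc1` gives 136 nM

Compound 2 stands second highest of the three numbers. Its nearest neighbour is compound 3, its furthest compound 1, and both of these gaps lie within the scatter of this assay, so no order among the three can be read from them.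

Within the data shown here, only one step between measured compounds differs in a single place: a 1.7-fold higher number from compound 1 to compound 2 (0.24 log units; within the scatter), methyl in place of hydrogen on a saturated ring carbon. It stayed within the scatter.

Compound 4 `CC(Sc1nc2nn(CC3COC3)cc2c(=O)n1-c1ccccc1)c1ccccc1` is the next member; it differs from compound 2 by (oxetan-3-yl)methyl in place of 3-methyloxetan-3-yl on an aromatic nitrogen. The two have the same atoms, joined differently. Among the measured compounds shown here, the one measured step that bears on this region of the structure, from compound 1 to compound 2, was small, and no measured pair shows a rearrangement of this kind, so there is no basis for expecting a move beyond the scatter in this assay in either direction.

The estimate for compound 4 in this assay is therefore 95 nM, with a range from 40 nM to 230 nM, which means an expected step of a 1.2-fold lower number from compound 2 to compound 4 (0.07 log units; within the scatter).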

Compound 4, half-maximal inhibitory concentration: 80 nM
Beside the measured number, compound 4's estimate is 1.2-fold (0.07 log units) above it; the measured number falls inside the stated range.
By their numbers in this assay, from the lowest: compounds 1, 4, 2 and 3 (each within the scatter of the next, the first and the last beyond it).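

In this assay, (oxetan-3-yl)methyl in place of 3-methyloxetan-3-yl on the aromatic nitrogen gives a 1.4-fold lower number from compound 2 to compound 4 (0.15 log units; within the scatter) and, in place of oxetan-3-yl, gives a 1.2-fold higher number from compound 1 to compound 4 (0.09 log units; within the scatter), so both new steps stay within the scatter. With the earlier step of a 1.7-fold higher number from compound 1 to compound 2 (0.24 log units; within the scatter), all three oxetane-bearing groups at this nitrogen now connect through steps within the scatter, and this holds even for the rearrangement of the same atoms between compound 2 and compound 4, so no preference among these groups can be read at this position. No accompanying measurement bears on why these changes leave the read-out within the scatter.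

Still open, as far as these compounds go, is whether a different kind of group on this aromatic nitrogen, such as an amine, a carboxylic acid or a longer chain carrying the oxetane, would produce a step beyond the scatter. Also open, from the compounds shown here alone, is whether the three oxetane-bearing groups would stay within the scatter of one another with the methoxy-bearing phenyl of compound 3 on the shared core.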